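Ester side-chain variation on a shared core

This account rests on a few compounds, and the source may have more. Where it says the series, first, only, none or still open, it means among the compounds named here.

Compound 1 `C#CCOC(=O)C[C@@H]1C(C(=O)OC)=CO[C@@H](O[C@@H]2O[C@H](CO)[C@@H](O)[C@H](O)[C@H]2O)/C1=C/C` is the reference point of these notes. In a functional assay on SK-BR-3 cells (Homo sapiens) for antiproliferative activity, read by MTT assay, with a stated time of 72 h (a lower number here means a stronger inhibitor, a higher number a weaker inhibitor), compound 1 gives only a limit, > 15000 nM, so no number is known for it. Two further members of the set are read in this assay and likewise reach no number. Compound 2 `C/C=C1/[C@H](O[C@@H]2O[C@H](COC(C)=O)[C@@H](OC(C)=O)[C@H](OC(C)=O)[C@H]2OC(C)=O)OC=C(C(=O)O)[C@H]1CC(=O)O` gives a limit, > 20000 nM. Compound 3 `C/C=C1/[C@H](O[C@@H]2O[C@H](COC(C)=O)[C@@H](OC(C)=O)[C@H](OC(C)=O)[C@H]2OC(C)=O)OC=C(C(=O)OC)[C@H]1CC(=O)OCCC(C)C` gives a limit, > 15000 nM. Across the three, the limit of > 15000 nM in this assay, at which 2 of the 3 values shown sit, and the limit of > 20000 nM in this assay, at which 1 of the 3 values shown sits, are the only readings, and they say nothing about how any change to the ester or the sugar part moves activity, since none of the three resolves into a value.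

Compound 4 `C/C=C1/[C@H](O[C@@H]2O[C@H](CO)[C@@H](O)[C@H](O)[C@H]2O)OC=C(C(=O)OC)[C@H]1CC(=O)OCCc1ccccc1` is the next member. It differs from compound 1 by benzyl in place of ethynyl on a saturated chain carbon bound to an oxygen next to a carbonyl group. Among the compounds with values here, no measured pair in the set differs at a single place, so no step size can be carried over, and the three limits give no direction for this change. Compound 4 is therefore expected to stay near the limit, with a step that the limit leaves unreadable from compound 1 to compound 4 that is expected to be none beyond the scatter. The estimate for compound 4 in this assay is 20000 nM, within a range from 8000 nM to 60000 nM, and most likely the reading will again be only a limit.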

Compound 4, half-maximal inhibitory concentration: 11000 nM
Estimate against measurement, compound 4: 1.8-fold (0.26 log units) above; the measured number falls inside the stated range.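

In this assay, within the data shown here, compound 4 gives 11000 nM, the first reading that is a number rather than a limit, so activity at this position can now be placed on a scale. Putting benzyl in place of ethynyl on a saturated chain carbon bound to an oxygen next to a carbonyl group gives an at least 1.3-fold lower number from compound 1 to compound 4 (0.13 log units; that floor lies within the scatter); this is only a floor, since the reading for compound 1 is a limit, and the true size of the step cannot be read from it, so a real gain is possible but not shown. The phenethyl ester therefore marks the one spot in the set where a value can be read, while the other readings remain limits and not numbers: the limit of > 15000 nM in this assay, at which 2 of the 4 values shown sit.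

From the compounds shown here alone, it remains open whether the phenyl ring of the phenethyl ester matters or whether any longer chain would do, and a plain hexyl ester or a phenethyl ester carrying an amine on the ring would separate the two. Also open, going by these compounds, is how the phenethyl ester behaves on the acetylated sugar, and how far a true number for compound 1 lies from compound 4.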